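The source may hold more compounds than are shown below. What is called first, only, known or untested is meant among the compounds shown, and "the series" means these compounds.

Compound 1 `CC(=O)OC[C@H]1O[C@@H](n2cc(Cn3cc(/C=C/C(=O)c4cccnc4)c4ccccc43)nn2)[C@H](OC(C)=O)[C@@H](OC(C)=O)[C@@H]1OC(C)=O` and compound 2 `CC(=O)OC[C@H]1O[C@@H](n2cc(Cn3cc(/C=C4/C(=O)Nc5ccccc54)c4ccccc43)nn2)[C@H](OC(C)=O)[C@@H](OC(C)=O)[C@@H]1OC(C)=O` share a common core and differ in one place, namely an at least 5.0-fold higher number from compound 1 to compound 2 (0.70 log units; beyond the scatter). In a functional assay on A549 cells (Homo sapiens) for cytotoxicity, read by sulforhodamine B assay, with a stated time of 48 h (on this read-out higher numbers stand for weaker inhibition and lower numbers for stronger inhibition), compound 1 gives 39800 nM. For compound 2 the same assay reports only a limit, > 200000 nM, so compound 2 stands at the weakest end of what this assay can resolve; the step from compound 1 is bounded by the limit of > 200000 nM in this assay, at which 1 of the 2 values shown sits.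

Compound 3 `CC(=O)OC[C@H]1O[C@@H](n2cc(Cn3cc(/C=C4/C(=O)Nc5ccc(F)cc54)c4ccccc43)nn2)[C@H](OC(C)=O)[C@@H](OC(C)=O)[C@@H]1OC(C)=O` differs from compound 2 by fluoro in place of hydrogen on an aromatic carbon. Among the measured compounds shown here, the single measured step, an at least 5.0-fold higher number from compound 1 to compound 2 (0.70 log units; beyond the scatter), concerns a different part of the molecule and gives no guidance on a fluoro substitution; no measured pair speaks to it. The author therefore expects no change beyond the scatter. Compound 3 is estimated at 200000 nM, with a range from 60000 nM to 400000 nM. The expected step is a number no higher from compound 2 to compound 3 (the limit leaves the size open), and the assay is expected most likely to report a limit again.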

Compound 3, half-maximal inhibitory concentration: 36900 nM
The estimate for compound 3 lay 5.4-fold (0.73 log units) above the measured number, outside the stated range (below it).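

Fluoro in place of hydrogen, on an aromatic carbon meta to a fused ring and para to a fused ring, gives an at least 5.4-fold lower number from compound 2 to compound 3 (0.73 log units; beyond the scatter) in this assay and so shows that this position responds to a single added atom, which the earlier compounds could not show. Compound 2 carries only a limit and not a number, so the size of that step remains a bound: the limit of > 200000 nM in this assay, at which 1 of the 3 values shown sits. With fluoro in place there is a 1.1-fold lower number from compound 1 to compound 3 (0.03 log units; within the scatter) within the scatter, whereas without it the same exchange gave an at least 5.0-fold higher number from compound 1 to compound 2 (0.70 log units; beyond the scatter) beyond the scatter.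

The compounds shown leave open whether another group on this carbon, such as chloro, methoxy or an amine, would act as fluoro does. They also leave open whether fluoro on another carbon of this ring would give the same step.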